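Replacing the 2,6-dichlorophenyl group in a cytotoxic series

A few compounds are considered here, and "the series" means these few. Any claim that something is new, unique, unknown or untested is made for them only; others in the source may bear on it.

Of the compounds shown here, three built on one shared core have been measured so far in a functional assay on K562 cells (Homo sapiens) for cytotoxicity, read by MTT assay, with a stated time of 48 h (on this read-out higher numbers stand for weaker inhibition and lower numbers for stronger inhibition), as the read-out. Compound 1 (`O=C(CN[C@H]1CCN(S(=O)(=O)Cc2ccccc2)C1)N1CCN(Cc2cccc(Cl)c2)CC1`) gives 8600 nM with a chloro group on an aromatic carbon. Compound 2 (`O=C(CN[C@H]1CCN(S(=O)(=O)Cc2ccccc2)C1)N1CCN(Cc2cccc(C(F)(F)F)c2)CC1`) gives 3600 nM with trifluoromethyl in that place. Compound 3 (`O=C(CN[C@H]1CCN(S(=O)(=O)Cc2ccccc2)C1)N1CCN(Cc2c(Cl)cccc2Cl)CC1`) gives 28400 nM with 2,6-dichlorophenyl on the same chain, which is the highest number of the three and the weakest inhibition.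

Compound 4 (`COc1ccc(CN2CCN(C(=O)CN[C@H]3CCN(S(=O)(=O)Cc4ccccc4)C3)CC2)cc1`) has not been measured. It differs from compound 3 by 4-methoxyphenyl in place of 2,6-dichlorophenyl on a saturated chain carbon bound to an amine nitrogen in a ring and so has 4-methoxyphenyl in place of 2,6-dichlorophenyl on a saturated chain carbon bound to an amine nitrogen in a ring.

Among the measured compounds shown here, no measured step involves 4-methoxyphenyl, so the closest evidence comes from the steps that bring in 2,6-dichlorophenyl. These are a 3.3-fold higher number from compound 1 to compound 3 (0.52 log units; beyond the scatter) and a 7.9-fold higher number from compound 2 to compound 3 (0.90 log units; beyond the scatter) and both are modest. The change from chloro to trifluoromethyl, a 2.4-fold lower number from compound 1 to compound 2 (0.38 log units; beyond the scatter), is modest as well. Leaving 2,6-dichlorophenyl is therefore expected to give a modest move towards a lower number. The expected step is a 2.8-fold lower number from compound 3 to compound 4 (0.45 log units; beyond the scatter) in this estimate. Compound 4 is estimated at 10000 nM within an expected range of 3500 nM to 30000 nM.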

Compound 4, half-maximal inhibitory concentration: 50900 nM
Compound 4: middle estimate off by 5.1-fold (0.71 log units), on the low side; the measured number lies above the stated range.
By their numbers in this assay, from the lowest: compound 2; then compound 1; then compounds 3 and 4 (each within the scatter of the next).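

In this assay the move from 2,6-dichlorophenyl to 4-methoxyphenyl on this saturated chain carbon brings no separation between the two groups (a 1.8-fold higher number from compound 3 to compound 4 (0.25 log units; within the scatter)), so 2,6-dichlorophenyl no longer stands alone at the high end of the series. Compounds 3 and 4 now sit together, apart from 3-chlorophenyl and 3-(trifluoromethyl)phenyl, and the step to 4-methoxyphenyl is modest from the chloro compound (a 5.9-fold higher number from compound 1 to compound 4 (0.77 log units; beyond the scatter)) and large from the trifluoromethyl compound (a 14-fold higher number from compound 2 to compound 4 (1.15 log units; beyond the scatter)), the widest gap among these four compounds. Nothing available explains why these groups fall out this way.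

From the compounds shown here alone, what an unsubstituted phenyl on this chain carbon would give remains open, and with it how much of the gap belongs to the methoxy group itself. Also open, going by these compounds, is whether a nitrile or a carboxylic acid on the aromatic ring would read like chloro and trifluoromethyl or like 4-methoxyphenyl.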